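Furan for thiophene on the shared core

The source may report more compounds than this note shows. Statements on the series, on what has been measured and on what is new or still open speak of the compounds shown alone.

Compound 3 `Nc1nc(N)c2c(-c3cccs3)cn([C@@H]3O[C@H](CO)[C@@H](O)[C@H]3O)c2n1` carries a thiophen-2-yl group on the shared core. In a functional assay on CCRF-CEM cells (Homo sapiens), read by MTT assay, with a stated time of 72 h (a higher number here means a weaker inhibitor, a lower number a stronger inhibitor), compound 3 gives > 20000 nM, which is a limit of the assay and not a number. The two compounds that differ from it in one place sit at the same limit. Compound 1 `Cc1nc(N)c2c(-c3cccs3)cn([C@@H]3O[C@H](CO)[C@@H](O)[C@H]3O)c2n1` gives > 20000 nM in this assay, a limit. Compound 2 `COc1nc(N)nc2c1c(-c1cccs1)cn2[C@@H]1O[C@H](CO)[C@@H](O)[C@H]1O` gives > 20000 nM in this assay, also a limit. The steps a step that the two limits leave unreadable from compound 1 to compound 3 and a step that the two limits leave unreadable from compound 2 to compound 3 therefore cannot be sized, because the limit of > 20000 nM in this assay, at which 3 of the 3 values shown sit, holds for every value shown.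

Compound 4 `Nc1nc(N)c2c(-c3ccco3)cn([C@@H]3O[C@H](CO)[C@@H](O)[C@H]3O)c2n1` differs from compound 3 by furan-2-yl in place of thiophen-2-yl on an aromatic carbon. No measured step bears on this exchange, and none of the shown values lies inside the readable range of this assay, so there is no basis for expecting a step beyond the scatter. Compound 4 is expected to give about 30000 nM in this assay, with a range from 10000 nM to 100000 nM, most likely reported again only as a limit. The expected step is a step that the limit leaves unreadable from compound 3 to compound 4, meaning no change that the assay would resolve.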

Compound 4, half-maximal inhibitory concentration: > 20000 nM
Compound 4 was reported as a limit; the forecaster's own chance of this, stated with the estimate: 80%; the middle value lies beyond the limit too.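

In this assay compound 4 gives > 20000 nM, a limit. No size can be read for furan-2-yl in place of thiophen-2-yl between compound 3 and compound 4, because both values sit at one limit: the limit of > 20000 nM in this assay, at which 4 of the 4 values shown sit.

The compounds shown leave open which change on the shared core, if any, would give a value inside the readable range of this assay.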